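Adding a methoxy to an inactive compound

This account rests on a few compounds, and the source may have more. Where it says the series, first, only, none or still open, it means among the compounds named here.

Measured so far in a functional assay on PC-3 cells (Homo sapiens) for cytotoxicity, read by MTT assay, with a stated time of 72 h; on this read-out lower numbers stand for stronger inhibition and higher numbers for weaker inhibition (three compounds):
Compound 1 `O=C(/C=C/c1cccc(Cl)c1Cl)Nc1cc2c(Nc3ccc(F)c(Cl)c3)ncnc2cc1O[C@H]1CCOC1` gives 27500 nM
Compound 2 `COc1ccc(/C=C/C(=O)Nc2cc3c(Nc4ccc(F)c(Cl)c4)ncnc3cc2OC)cc1` gives "not active" (no number reported)
Compound 3 `COc1ccc(/C=C/C(=O)Nc2cc3c(Nc4ccc(F)c(Cl)c4)ncnc3cc2O[C@H]2CCOC2)c(OC)c1OC` gives 7670 nM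

Compound 2 has no number to start from, because it is reported only as "not active" (no number reported) and nothing shows how far from activity it lies. Compound 4 (`COc1cc(/C=C/C(=O)Nc2cc3c(Nc4ccc(F)c(Cl)c4)ncnc3cc2OC)cc(OC)c1`) differs from it in one place, and the change reads 3,5-dimethoxyphenyl in place of 4-methoxyphenyl on a double-bonded chain carbon bound to a double-bonded chain carbon in full. The group on the chain therefore goes from one methoxy to two.

Among the compounds with values here, only one measured step offers any guide. That step, a 3.6-fold lower number from compound 1 to compound 3 (0.55 log units; beyond the scatter), is modest and swaps 2,3-dichlorophenyl for 2,3,4-trimethoxyphenyl. It is an imperfect guide, since compound 1 and compound 3 also carry a different group elsewhere from compound 2 and compound 4. A simple rule that methoxy groups help is also contradicted by compound 2, which carries one and still gives "not active" (no number reported).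

No step size can be calculated from compound 2. The expectation is, at best, a modest move towards a lower number, and compound 4 may equally stay without one. Compound 4 is expected near 25000 nM, with an estimated range from 8000 nM to 80000 nM.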

Compound 4, half-maximal inhibitory concentration: "not active" (no number reported)
Compound 4: no number reported, and the estimate cannot be compared.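

Within the data shown here, compound 2 and compound 4 are both reported only as "not active", with no number, so no step between them can be read. No other measurement shown bears on this result. The compounds shown leave open how far each lies from activity, and whether 3,5-dimethoxyphenyl in place of 4-methoxyphenyl shifts it at all.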